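Isopropoxy for isopropyl on the carbonyl of compound 3

The source may hold more compounds than are shown below. What is called first, only, known or untested is meant among the compounds shown, and "the series" means these compounds.

Measured compounds:
compound 1, `CC(=O)N1CCC(C(=O)N2CCC(N3CCN(C(=O)c4cc(-c5ccc(C)cc5)nc(-c5ccc(C)cc5)c4)CC3)CC2)CC1`, 343 nM
compound 2, `CC(=O)N1CCC(C(=O)N2CCC(N3CCN(C(=O)c4cc(-c5ccc(C)cc5)nc(-c5ccc6[nH]c(C)c(C)c6c5)c4)CC3)CC2)CC1`, 294 nM
compound 3, `CCNC(=O)Nc1sc2ccccc2c1C(=O)N1CCN(C2CCN(C(=O)C(C)C)CC2)CC1`, "not determined" (no result reported)

Compound 1 and compound 2 share a core and were both tested in a functional assay on HepG2 cells (Homo sapiens) for inhibition, read by scintillation counting, with a stated time of 2 h (on this read-out higher numbers stand for weaker inhibition and lower numbers for stronger inhibition), where compound 1 gives 343 nM and compound 2 gives 294 nM; the change between them is a 1.2-fold lower number from compound 1 to compound 2 (0.07 log units; within the scatter). Compound 3 belongs to a different core, and for compound 3 this assay reports "not determined" (no result reported), so compound 3 stands nowhere on the numbers shown.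

Compound 4, `CCNC(=O)Nc1sc2ccccc2c1C(=O)N1CCN(C2CCN(C(=O)OC(C)C)CC2)CC1`, differs from compound 3 in one place: isopropoxy in place of isopropyl on a carbonyl carbon. Among the compounds with values here, no measured step bears on this change. Within the data shown here, the only step in hand, from compound 1 to compound 2, concerns a different core and a different kind of exchange, on an aromatic carbon rather than on a carbonyl carbon, so nothing can be said about the size or direction of the step from compound 3 to compound 4 in this assay.

With no anchor for compound 3, the expectation for compound 4 can rest only on the level at which compound 1 and compound 2 sit in this assay. Compound 4 is therefore estimated at 300 nM, within a wide range from 50 nM to 2000 nM.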

Compound 4, half-maximal inhibitory concentration: 208 nM
Compound 4: the middle estimate sits 1.4-fold (0.16 log units) above what was measured; the measured number falls inside the stated range.
By their numbers in this assay, from the lowest: compounds 4, 2 and 1 (each within the scatter of the next).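

In this assay compound 4 gives 208 nM, while compound 3 has no number to set against it; no step can be read between the two. No evidence on hand bears on this result. The compounds shown leave open what replacing isopropyl with isopropoxy on this carbonyl carbon does in this read-out.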